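Carboxy in Place of Nitro: Expected Cytotoxicity

A few compounds are considered here, and "the series" means these few. Any claim that something is new, unique, unknown or untested is made for them only; others in the source may bear on it.

Compound 1 `CCOC(=O)c1cn(-c2cccc([N+](=O)[O-])c2)nc1CC(C)C`: 59300 nM
Compound 2 `CCOC(=O)c1cn(-c2ccc(C(=O)O)cc2)nc1CC(C)C`: > 100000 nM

Of the compounds shown here, two have been measured in a toxicity assay on HepG2 2.2.15 cells (Homo sapiens) for cytotoxicity, read by CCK-8 assay, with a stated time of 8 days; on this read-out lower numbers stand for higher toxicity in this test and higher numbers for lower toxicity in this test. Compound 1 gives 59300 nM in this assay, the only plain number shown. For compound 2 this assay reports only a limit of > 100000 nM, not a number, so that (the limit of > 100000 nM in this assay, at which 1 of the 2 values shown sits). Compound 1 therefore stands as the sole point with a definite value, and the other reading lies at the limit. Going by the values given here, no pair of measured compounds differs in one place, so no measured step exists.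

Compound 3 `CCOC(=O)c1cn(-c2cccc(C(=O)O)c2)nc1CC(C)C` has not yet been measured. It differs from compound 1 by carboxy in place of nitro on an aromatic carbon. Among the compounds with values here, the only other carboxy-bearing compound, compound 2, sat at the limit in this assay, which points toward lower toxicity for compound 3 as well. The step of a 1.9-fold higher number from compound 1 to compound 3 (0.27 log units; within the scatter) is expected to exceed the scatter in the direction of lower toxicity. Compound 3 is estimated at 110000 nM, with a range from 50000 nM to 250000 nM, and a sizeable chance that this assay reports only a limit.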

Compound 3, half-maximal cytotoxic concentration: 7100 nM
Estimate against measurement, compound 3: 15-fold (1.19 log units) above; measured number outside the range, below it.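

In this assay, carboxy in place of nitro on an aromatic carbon, meta to a large group, gives an 8.4-fold lower number from compound 1 to compound 3 (0.92 log units; beyond the scatter), a step toward higher toxicity in this test. Going by these compounds alone, this is the first measured step, and it shows that a carboxy group at this position of the six-membered aromatic ring does not by itself go with a low toxicity reading, since compound 3 carries one and still reads clearly lower than the nitro compound. Compound 2, the other carboxy-bearing compound, gives only a limit and not a number, so its reading says nothing definite about how far carboxy compounds can differ from one another: the limit of > 100000 nM in this assay, at which 1 of the 3 values shown sits.

On these data alone, whether an amine, a nitrile or a methyl ester at the same place would read closer to compound 3 or to compound 1 remains open, so the step cannot yet be tied to carboxy alone or to the loss of nitro. Also open, as far as these compounds go, is whether the step would keep its direction and size with a longer chain on the shared core, or with a carboxylic acid in place of the ethyl ester.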